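Lipophilicity: 2-bromophenyl to 4-chlorophenyl swap in a small set

This account rests on a few compounds, and the source may have more. Where it says the series, first, only, none or still open, it means among the compounds named here.

Working notes on four compounds sharing a carbonyl linked to an amide-type nitrogen. Compound 1 `O=C(N/N=C/c1cccc([N+](=O)[O-])c1)c1ccccc1Br` is the starting point; in a physicochemical assay for lipophilicity (on this read-out higher numbers stand for higher lipophilicity and lower numbers for lower lipophilicity), compound 1 gives 4.17. Compound 2 `O=C(N/N=C/c1cccc([N+](=O)[O-])c1)c1ccc(Cl)cc1` carries the change (4-chlorophenyl in place of 2-bromophenyl on a carbonyl carbon), and in this assay compound 2 gives 3.9. The step for this change is a number 0.27 log units lower from compound 1 to compound 2 (within the scatter), so within this pair the swap leaves the read-out essentially unmoved.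

Compound 3 `COc1ccc(/C=N/NC(=O)c2ccccc2Br)cc1OC` sits on a different core; how the core of compound 1 and the core of compound 3 differ is not broken down here. In this assay compound 3 gives 3.71, which is within the scatter of the value of compound 2 and beyond the scatter below the value of compound 1.

Compound 4 `COc1ccc(/C=N/NC(=O)c2ccc(Cl)cc2)cc1OC` is not yet measured. It differs from compound 3 by 4-chlorophenyl in place of 2-bromophenyl on a carbonyl carbon, the same change as from compound 1 to compound 2, occurring twice in all across these compounds and at the same kind of place on the carbonyl carbon.

For the measured compounds named here, for compound 4 the expected step is a number 0.27 log units lower from compound 3 to compound 4 (within the scatter), because the single precedent for this change gave a number 0.27 log units lower from compound 1 to compound 2 (within the scatter). Compound 4 is therefore estimated at 3.44 in this assay. Going by the values given here, for compound 4 the expected range runs from 3.14 to 3.74, widened somewhat since only one measured pair supports the transfer of this step onto the core of compound 3.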

Compound 4, partition coefficient: 3.44
Compound 4: the middle estimate sits on the measured number at the digits printed; the measured number falls inside the stated range.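

In this assay the swap of 2-bromophenyl for 4-chlorophenyl on a carbonyl carbon gives a number 0.27 log units lower from compound 3 to compound 4 (within the scatter), the same size at the printed digits as a number 0.27 log units lower from compound 1 to compound 2 (within the scatter), so the step carried from the core of compound 1 to the core of compound 3 without any visible change in size. Both steps lie within the scatter, however, so what has carried over is a small step that repeated measurement alone could produce, and neither pair establishes that the swap truly shifts the read-out on its core. Two cores give no basis for a rule on any further core, and nothing available here explains why the two steps match.

The compounds shown have only these two halogen-bearing phenyl groups on the carbonyl carbon, so it remains open whether a step of similar size would be seen on both cores with a different group there, such as an amine, a carboxylic acid or a longer chain. As far as these compounds go, it also remains open whether a swap giving a step beyond the scatter on one core would transfer as closely to the other.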